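The source may report more compounds than this note shows. Statements on the series, on what has been measured and on what is new or still open speak of the compounds shown alone.

Measured compounds in a functional assay on HT-29 cells (Homo sapiens) for antiproliferative activity, read by MTT assay, with a stated time of 72 h; on this read-out lower numbers stand for stronger inhibition and higher numbers for weaker inhibition:

Compound 1, `COc1cc(/C=C2\CCC/C(=C\c3ccc(O)c(O)c3)C2=O)cc(OC)c1OC` — 8500 nM
Compound 2, `COc1cc(/C=C2\CCC/C(=C\c3ccccc3Br)C2=O)cc(OC)c1OC` — 2800 nM
Compound 3, `COc1cc(/C=C2\CCC/C(=C\c3ccccc3F)C2=O)cc(OC)c1OC` — 1600 nM

Compound 3 gives the lowest number of the three, but its separation from compound 2 is small: a 1.8-fold lower number from compound 2 to compound 3 (0.24 log units; within the scatter), so the two cannot be ranked against each other. Compound 1 stands clearly apart, as a 5.3-fold lower number from compound 1 to compound 3 (0.73 log units; beyond the scatter) and a 3.0-fold lower number from compound 1 to compound 2 (0.48 log units; beyond the scatter) show, both beyond the scatter.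

The unmeasured compound 4, `COc1cc(/C=C2\CCC/C(=C\c3cccc(O)c3)C2=O)cc(OC)c1OC`, differs from compound 3 in one place: 3-hydroxyphenyl in place of 2-fluorophenyl on a double-bonded chain carbon bound to a double-bonded ring carbon. Within the data shown here, the steps that bear on this are the two that exchanged the 3,4-dihydroxyphenyl of compound 1 for a halogen-bearing phenyl: a 3.0-fold lower number from compound 1 to compound 2 (0.48 log units; beyond the scatter) and a 5.3-fold lower number from compound 1 to compound 3 (0.73 log units; beyond the scatter). Both moved the number downward when hydroxyl groups left the ring. Compound 4 brings one hydroxyl group back, but only one, and at a different place on the ring than in compound 1, so a partial reversal seems the most likely outcome in this assay, with the number expected to rise from compound 3, though less than the full gap back to compound 1.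

Compound 4 is therefore estimated at 4000 nM, with a likely range from 1500 nM to 11000 nM; the expected step is a 2.5-fold higher number from compound 3 to compound 4 (0.40 log units; beyond the scatter).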

Compound 4, half-maximal inhibitory concentration: 7600 nM
Beside the measured number, compound 4's estimate is 1.9-fold (0.28 log units) below it, within the range that was stated.
By their numbers in this assay, from the lowest: compounds 3 and 2 (each within the scatter of the next); then compounds 4 and 1 (each within the scatter of the next).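

At this place, on a double-bonded chain carbon bound to a double-bonded ring carbon, the exchange of a halogen-bearing phenyl for 3-hydroxyphenyl weakens inhibition in this assay: 2-fluorophenyl gives way with a 4.8-fold higher number from compound 3 to compound 4 (0.68 log units; beyond the scatter) and 2-bromophenyl with a 2.7-fold higher number from compound 2 to compound 4 (0.43 log units; beyond the scatter) and both steps are larger than the usual scatter. The step of a 1.1-fold lower number from compound 1 to compound 4 (0.05 log units; within the scatter) shows that 3-hydroxyphenyl and 3,4-dihydroxyphenyl cannot be told apart here, so among these four compounds the two hydroxy-bearing phenyls stand together and the two halogen-bearing phenyls stand together, with no compound going against that split. Nothing available here explains this split.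

The compounds shown cannot say whether the hydroxy group raises the number or the halogens lower it, and a plain phenyl with neither group at this place would separate those two readings. As far as these compounds go, it also remains open how other groups on this ring would behave, such as a methoxy group, an amine or a carboxylic acid, and whether the split would hold for them.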